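Aryl urea substituent steps in a kinase inhibitor series

The compounds below may be only part of what the source reports. "The series", "measured", "known", "first", "only" and "open" are said of these compounds alone.

Measured compounds:
Compound 1 `O=C(Nc1ccc(Cl)cc1)Nc1ccc(Nc2ncnc3c2OCCN3)cc1` in an assay on isolated protein for inhibition of proto-oncogene tyrosine-protein kinase receptor Ret variant V804L (Homo sapiens), read by 33P incorporation, with stated times of 15 min and 40 min (on this read-out lower numbers stand for stronger inhibition and higher numbers for weaker inhibition), gives > 10000 nM, which is a limit of the assay and not a number.
Compound 2 `Cc1cc(C)cc(NC(=O)Nc2ccc(Nc3ncnc4c3OCCN4)cc2)c1` in this assay gives 3770 nM.

Among the measured compounds shown here, compound 2 therefore holds the only numerical value in this assay; the remaining entry, for compound 1, is a limit (the limit of > 10000 nM in this assay, at which 1 of the 2 values shown sits). The step from the first to the second compound, 3,5-dimethylphenyl in place of 4-chlorophenyl on an amide-type nitrogen, gives an at least 2.6-fold lower number from compound 1 to compound 2 (0.42 log units; beyond the scatter).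

Compound 3 `O=C(Nc1ccc(Nc2ncnc3c2OCCN3)cc1)Nc1cc(Cl)cc(Cl)c1` has not yet been measured in this assay. Its difference from compound 2 is 3,5-dichlorophenyl in place of 3,5-dimethylphenyl on an amide-type nitrogen. For the measured compounds named here, only one measured step bears on it, an at least 2.6-fold lower number from compound 1 to compound 2 (0.42 log units; beyond the scatter), and that step changes both the substitution pattern and the type of substituent at once, so it speaks only loosely to the present change, which keeps the 3,5-pattern and exchanges methyl for chlorine. Going by the values given here, the one chlorine-bearing compound, compound 1, sits at the limit (the limit of > 10000 nM in this assay, at which 1 of the 2 values shown sits). The estimate for compound 3 is 3000 nM, with a range from 800 nM to 12000 nM, which means an expected step of a 1.3-fold lower number from compound 2 to compound 3 (0.10 log units; within the scatter), with wide uncertainty in either direction.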

Compound 3, half-maximal inhibitory concentration: 4480 nM
The estimate for compound 3 lay 1.5-fold (0.17 log units) below the measured number; measured number inside the range.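

3,5-dichlorophenyl in place of 3,5-dimethylphenyl on an amide-type nitrogen gives a 1.2-fold higher number from compound 2 to compound 3 (0.07 log units; within the scatter), so in this assay these two groups cannot be told apart at this position. 3,5-dichlorophenyl in place of 4-chlorophenyl on the same nitrogen gives an at least 2.2-fold lower number from compound 1 to compound 3 (0.34 log units; beyond the scatter); chlorine stands on both sides of this step, so the lower number seen with compound 2 does not depend on methyl as such, and among these three compounds both 3,5-disubstituted rings read lower than the 4-chlorophenyl ring. Compound 1 remains a limit of the assay and not a number, so these steps have only a lower bound on their size: the limit of > 10000 nM in this assay, at which 1 of the 3 values shown sits.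

The compounds shown do not separate the effect of the 3,5-pattern from that of carrying two substituents, and a plain phenyl ring would be needed as a reference for both. Going by these compounds, it also remains open whether methoxy, trifluoromethyl or an amine in the place of these chlorines would move the number beyond the scatter, or whether this position stays as flat as the methyl and chlorine pair suggests.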